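The source may hold more compounds than are shown below. What is called first, only, known or untested is meant among the compounds shown, and "the series" means these compounds.

Compound 1 `COC(=O)c1cc(-c2cccc(NC(=O)c3ccc(/C=C/C(=O)c4cccc([N+](=O)[O-])c4)cc3)c2)on1` is the starting point. In an ADME assay on Vero cells (Chlorocebus sabaeus) for cytotoxicity, read by MTT assay, with a stated time of 72 h (on this read-out lower numbers stand for higher toxicity in this test and higher numbers for lower toxicity in this test), compound 1 gives > 40 ug/mL, which is a limit of the assay rather than a number. Its two neighbours are also known only as limits. Compound 2 `COC(=O)c1cc(-c2cccc(NC(=O)c3ccc(/C=C/C(=O)c4ccc(Br)cc4)cc3)c2)on1` gives > 20 ug/mL in this assay, again a limit. Compound 3 `COC(=O)c1cc(-c2cccc(NC(=O)c3ccc(/C=C/C(=O)c4ccc(C)c([N+](=O)[O-])c4)cc3)c2)on1` gives > 80 ug/mL in this assay, once more a limit. Accordingly the steps a step that the two limits leave unreadable from compound 1 to compound 2, a step that the two limits leave unreadable from compound 1 to compound 3 and a step that the two limits leave unreadable from compound 2 to compound 3 cannot be read in size; the three values sit at the limit of > 20 ug/mL in this assay, at which 1 of the 3 values shown sits, the limit of > 40 ug/mL in this assay, at which 1 of the 3 values shown sits, and (the limit of > 80 ug/mL in this assay, at which 1 of the 3 values shown sits).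

Compound 4 `COC(=O)c1cc(-c2cccc(NC(=O)c3ccc(/C=C/C(=O)c4ccc(F)cc4F)cc3)c2)on1` differs from compound 1 in one place: 2,4-difluorophenyl in place of 3-nitrophenyl on a carbonyl carbon. The step from compound 1 to compound 2, which also swaps the group on the carbonyl carbon, is the one that bears on it, but it is unreadable. Nothing in the three limits points to toxicity appearing, so for compound 4 a step that the limit leaves unreadable from compound 1 to compound 4 that stays within the scatter is expected, most likely as another limit. Compound 4 is therefore estimated at 60 ug/mL, within 30 ug/mL to 120 ug/mL.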

Compound 4, half-maximal cytotoxic concentration: > 40 ug/mL
Compound 4 ended at the assay's limit (the forecaster's own chance of this, stated with the estimate: 80%); the middle value lies beyond the limit too.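

Compound 4, like compound 1, compound 2 and compound 3, is known in this assay only as a limit, so none of its steps can be read in size. The compounds shown leave open whether the group on the carbonyl carbon changes cytotoxicity at all.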